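The source may report more compounds than this note shows. Statements on the series, on what has been measured and on what is new or still open speak of the compounds shown alone.

In a functional assay on L1210 cells (Mus musculus) for inhibition (on this read-out lower numbers stand for stronger inhibition and higher numbers for weaker inhibition), compound 1 `Nc1nc(O)c2ncn(C/C=C/CO)c2n1` gives 200000 nM. Compound 2 `Nc1nc(O)c2ncn(C=C=CCO)c2n1` has no number in this assay, only a limit of the assay, > 350000 nM. For the measured compounds named here, the one measured step, an at least 1.7-fold higher number from compound 1 to compound 2 (0.24 log units; that floor lies within the scatter), is a floor within the scatter, so it shows no firm difference between the two. Compound 3 `Nc1nc(O)c2ncn(C3C=CCO3)c2n1` has the same atoms as compound 2, joined differently: a group of 5 heavy atoms (4 carbon, 1 oxygen; one five-membered non-aromatic ring with 1 hetero atom) in place of a group of 5 heavy atoms (4 carbon, 1 oxygen; no ring), on an aromatic nitrogen. A ring-bearing group thus replaces the open chain on the aromatic nitrogen. Going by the values given here, no measured step covers such a ring, and the only guide is an at least 1.7-fold higher number from compound 1 to compound 2 (0.24 log units; that floor lies within the scatter), which concerns open chains alone. In this assay, a weak result is therefore expected, with no change beyond the scatter. The expected step, an at least 1.1-fold lower number from compound 2 to compound 3 (0.06 log units; that floor lies within the scatter), reflects this. For compound 3 the estimated value is 300000 nM, with an expected range from 120000 nM to 700000 nM.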

Compound 3, half-maximal inhibitory concentration: > 350000 nM
Compound 3 ended at the assay's limit (the forecaster's own chance of this, stated with the estimate: 60%); at least 1.1-fold (0.06 log units) between middle value and limit.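

In this assay compound 3 has only a limit of the assay, > 350000 nM. For the compounds shown here, a group with one five-membered non-aromatic ring with 1 hetero atom on the aromatic nitrogen therefore yields no number here, just as the open chain 4-hydroxybuta-1,2-dien-1-yl did, and the one readable step, an at least 1.7-fold higher number from compound 1 to compound 3 (0.24 log units; that floor lies within the scatter), is a floor within the scatter, so it shows no firm difference. The step between the two limit compounds cannot be read, because neither has a number in the assay: the limit of > 350000 nM in this assay, at which 2 of the 3 values shown sit.

The compounds shown leave open how far the true values of compound 2 and compound 3 lie from each other or from that of compound 1. They also leave open whether a longer chain or an amine on this aromatic nitrogen would give a number clearly different from that of compound 1, 200000 nM.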